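The source may report more compounds than this note shows. Statements on the series, on what has been measured and on what is new or still open speak of the compounds shown alone.

In a functional assay (trachea) with Cavia porcellus as the target (on this read-out higher numbers stand for an effect only at larger amounts of compound and lower numbers for an effect already at smaller amounts), compound 1 `CCCn1c(=O)n(CC)c(=O)c2[nH]cnc21` gives 1300 nM, compound 2 `CCCn1c(=O)n(CC(=O)O)c(=O)c2[nH]cnc21` gives 41000 nM and compound 3 `CCCn1c(=O)n(CCC(=O)O)c(=O)c2[nH]cnc21` gives 21200 nM. The two carboxy compounds sit together at the high end, with a 1.9-fold lower number from compound 2 to compound 3 (0.29 log units; within the scatter). Compound 3 stays far from the compound without carboxy, with a 16-fold higher number from compound 1 to compound 3 (1.21 log units; beyond the scatter), and the other carboxy compound shows a similar gap, with a 32-fold higher number from compound 1 to compound 2 (1.50 log units; beyond the scatter). Compound 4 `CCCn1c(=O)n(CCC(N)=O)c(=O)c2[nH]cnc21` carries amino in place of hydroxy on a carbonyl carbon, so 2-carboxyethyl becomes 2-carbamoylethyl (amino in place of hydroxy on a carbonyl carbon). Among the measured compounds shown here, no measured step tests this swap directly. Since the carboxy is gone, part of a 16-fold higher number from compound 1 to compound 3 (1.21 log units; beyond the scatter) may be undone, so a moderately lower number is expected in this assay. The expected step is a 3.0-fold lower number from compound 3 to compound 4 (0.48 log units; beyond the scatter). Compound 4 is estimated at 7000 nM, within an expected range of 2000 nM to 22000 nM.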

Compound 4, half-maximal effective concentration: 13100 nM
For compound 4 the middle estimate is 1.9-fold (0.27 log units) below the measured one, and the stated range covers the measured number.
By their numbers in this assay, from the lowest: compound 1; then compounds 4, 3 and 2 (each within the scatter of the next, the first and the last beyond it).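

The swap of amino for hydroxy on a carbonyl carbon brings no clear shift in this assay, with a 1.6-fold lower number from compound 3 to compound 4 (0.21 log units; within the scatter). So the high numbers do not need the carboxy itself, as a 10-fold higher number from compound 1 to compound 4 (1.00 log units; beyond the scatter) still shows a gap from the compound without either end group. The step of a 3.1-fold lower number from compound 2 to compound 4 (0.50 log units; beyond the scatter) is beyond the scatter, but it combines the end-group swap with a longer chain. Nothing available explains why these end groups read alike. From the compounds shown here alone, whether a 2-hydroxyethyl chain, an amine or a methyl ester at the chain end would return toward compound 1 stays open.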